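Changing the Aryl Group and the Expected Binding Number

The compounds below may be only part of what the source reports. "The series", "measured", "known", "first", "only" and "open" are said of these compounds alone.

Compound 1: `O=C1c2ccccc2S(=O)(=O)N1CCCCCCN1CCN(c2ccccc2F)CC1` — 322 nM
Compound 2: `O=C1c2ccccc2S(=O)(=O)N1CCCCCCN1CCN(c2cccc(Cl)c2Cl)CC1` — 119 nM

Of the compounds shown here, two sharing one core have been tested in an ADME assay on HEK293 cells for displacement of a labelled ligand from 5-hydroxytryptamine receptor 7 (Homo sapiens), read by radioligand binding, with a stated time of 1 h; on this read-out higher numbers stand for weaker inhibition and lower numbers for stronger inhibition. Compound 1 `O=C1c2ccccc2S(=O)(=O)N1CCCCCCN1CCN(c2ccccc2F)CC1` gives 322 nM, while compound 2 `O=C1c2ccccc2S(=O)(=O)N1CCCCCCN1CCN(c2cccc(Cl)c2Cl)CC1` gives 119 nM. Within the data shown here, compound 2 thus holds the lowest number of the two, and its only neighbour, compound 1, lies beyond the usual scatter. Among the measured compounds shown here, the one measured step, a 2.7-fold lower number from compound 1 to compound 2 (0.43 log units; beyond the scatter), came from putting 2,3-dichlorophenyl in place of 2-fluorophenyl on an amine nitrogen in a ring.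

Compound 3 `COc1cccc(N2CCN(CCCCCCN3C(=O)c4ccccc4S3(=O)=O)CC2)c1` is not yet measured. It differs from compound 2 in one place: 3-methoxyphenyl in place of 2,3-dichlorophenyl on an amine nitrogen in a ring. For the measured compounds named here, the single measured step concerns a different exchange at the same ring nitrogen, so it bears on this change only loosely, showing that swapping the aryl group there can move the number modestly. The entering group is not the 2,3-dichlorophenyl that gave compound 2 its 119 nM, so a modest rise, or no change beyond the scatter, is expected. The expected step is a 2.1-fold higher number from compound 2 to compound 3 (0.32 log units; beyond the scatter). Compound 3 is estimated at about 250 nM in this assay, within a range from 80 nM to 800 nM.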

Compound 3, inhibition constant: 305 nM
Compound 3: the middle estimate sits 1.2-fold (0.09 log units) below what was measured; the range from low to high includes it.
By their numbers in this assay, from the lowest: compound 2; then compounds 3 and 1 (each within the scatter of the next).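

In this assay the step of a 2.6-fold higher number from compound 2 to compound 3 (0.41 log units; beyond the scatter) shows that a new aryl group at this ring nitrogen does not by itself keep the low number of compound 2: 3-methoxyphenyl does not match 2,3-dichlorophenyl here. The comparison a 1.1-fold lower number from compound 1 to compound 3 (0.02 log units; within the scatter) puts 3-methoxyphenyl and 2-fluorophenyl level, so among these three compounds only 2,3-dichlorophenyl stands apart, even though the other two aryl groups carry different substituents. No measurement shown here explains why this group stands apart.

The compounds shown leave open whether a single chlorine, as in 3-chlorophenyl, would be enough to give a number like that of compound 2. They also leave open how 2-methoxyphenyl, or a shorter chain on the shared core, would score.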